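The compounds below may be only part of what the source reports. "The series", "measured", "known", "first", "only" and "open" are said of these compounds alone.

Measured so far:
- compound 1 `CC1(c2ccccc2)CC(=O)N(CC(=O)N2CCN(c3ccccc3F)CC2)C1=O`: 300 mg/kg
- compound 2 `Cc1cccc(N2CCN(C(=O)CN3C(=O)CC(C)(c4ccccc4)C3=O)CC2)c1`: "not active" (no number reported)
- compound 3 `COc1cccc(N2CCN(C(=O)CN3C(=O)CC(C)(c4ccccc4)C3=O)CC2)c1`: "not active" (no number reported)

Among the compounds with values here, in a functional assay on the whole organism (strain CD-1) with Mus musculus as the target, with a stated time of 2 h (on this read-out lower numbers stand for an effect already at smaller amounts and higher numbers for an effect only at larger amounts of compound), compound 1 is the only member of the series with a single number, giving 300 mg/kg. Compound 2 is reported in this assay as "not active" (no number reported) with no number. Compound 3 likewise stands in this assay as "not active" (no number reported), so no number places it, and a second entry of the series shares that position without a number. The shared core of compound 3 is kept throughout; the three measured compounds differ only in the aromatic group on the amine nitrogen in a ring.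

Compound 4 `COc1ccccc1N1CCN(C(=O)CN2C(=O)CC(C)(c3ccccc3)C2=O)CC1` is not yet measured. It differs from compound 3 as 2-methoxyphenyl in place of 3-methoxyphenyl on an amine nitrogen in a ring. Within the data shown here, no step between measured compounds has been computed, and compound 3 has no number, so no size for the step into compound 4 can be given; the expectation in this assay is a move toward a reportable dose, in the direction of compound 1, rather than none beyond the scatter. Compound 4 is therefore estimated to give 300 mg/kg in this assay, within a range of 100 mg/kg to 1000 mg/kg, with a real chance that only a limit is reported.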

Compound 4, minimum effective dose: "not active" (no number reported)
For compound 4 the study gives words and no number; there is nothing to compare the estimate with.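

In this assay compound 3 and compound 4 are both reported in words without a number, so no step can be read between them. No evidence bears on this result. The compounds shown leave open whether 2-methoxyphenyl and 3-methoxyphenyl differ at all on this read-out.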